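Cytotoxicity notes on the alkynyl bicyclic nucleoside series

The source may report more compounds than this note shows. Statements on the series, on what has been measured and on what is new or still open speak of the compounds shown alone.

For the measured compounds named here, compound 2 `CCCCCCCCCCC#Cc1cc2cn([C@@H]3O[C@H](CO)[C@@H](O)[C@@H]3O)c(=O)nc2o1` is the only member with a number in a functional assay on HEL cells (Homo sapiens) for cytotoxicity (on this read-out higher numbers stand for lower toxicity in this test and lower numbers for higher toxicity in this test), where compound 2 gives 46000 nM. Compound 1 `CCCCCCCCCCC#Cc1cc2cn(C)c(=O)nc2o1` gives in this assay only a limit, > 150000 nM. Going by the values given here, the single measured step, an at least 3.2-fold lower number from compound 1 to compound 2 (0.51 log units; beyond the scatter), rests on the limit of > 150000 nM in this assay, at which 1 of the 2 values shown sits, and concerns the group on the aromatic nitrogen, not the sugar. Compound 3 `CCCCCCCCCCC#Cc1cc2cn([C@H]3C[C@H](O)[C@@H](CO)O3)c(=O)nc2o1` differs from compound 2 by hydrogen in place of hydroxy on a saturated ring carbon. Among the compounds with values here, no measured step touches this change, so no step beyond the scatter is expected in this assay: a 1.1-fold higher number from compound 2 to compound 3 (0.04 log units; within the scatter). Compound 3 is estimated at 50000 nM, within 20000 nM to 150000 nM.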

Compound 3, minimum cytotoxic concentration: 30000 nM
Compound 3: the middle estimate sits 1.7-fold (0.22 log units) above what was measured, within the range that was stated.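

Hydrogen in place of hydroxy on this saturated ring carbon gives, in this assay, a 1.5-fold lower number from compound 2 to compound 3 (0.19 log units; within the scatter), so the number does not depend measurably on this hydroxy. The lower number relative to the methyl compound therefore does not need this hydroxy, as an at least 5.0-fold lower number from compound 1 to compound 3 (0.69 log units; beyond the scatter) also shows. That step has a limit on the side of compound 1, not a number: the limit of > 150000 nM in this assay, at which 1 of the 3 values shown sits.

On these data alone, whether an amine or fluorine on this ring carbon would read the same stays open. So does whether the hydroxy remains as dispensable with a shorter or longer chain on the alkyne.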